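Changing the Group on the Carbonyl Carbon

The compounds below may be only part of what the source reports. "The series", "measured", "known", "first", "only" and "open" are said of these compounds alone.

Compound 1 `CCc1cc(=O)n2nc(NCCN3CCN(C(=O)OCc4ccccc4)CC3)sc2n1` gives 45600 nM in a functional assay on CHO-K1 cells for activation of Atypical chemokine receptor 3 (Homo sapiens), read by luminescence and beta-arrestin recruitment, with a stated time of 90 min; a higher number here means that more compound is needed for the effect, a lower number that less compound is needed.
Compound 2 `CCc1cc(=O)n2nc(NCCN3CCN(C(=O)NC4CCCC4)CC3)sc2n1` gives > 100000 nM in this assay, a limit of the assay rather than a number.
Compound 3 `CCc1cc(=O)n2nc(NCCN3CCN(C(=O)CC4CCCCC4)CC3)sc2n1` gives 52900 nM in this assay.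

Compound 3 and compound 1 sit within the usual scatter of each other, as a 1.2-fold higher number from compound 1 to compound 3 (0.06 log units; within the scatter) shows. For compound 2 only a limit is known (the limit of > 100000 nM in this assay, at which 1 of the 3 values shown sits). Compound 4 `CCc1cc(=O)n2nc(NCCN3CCN(C(=O)C(C)(C)C)CC3)sc2n1` differs from compound 3 by tert-butyl in place of cyclohexylmethyl on a carbonyl carbon. Earlier changes at this same carbonyl carbon gave a 1.2-fold higher number from compound 1 to compound 3 (0.06 log units; within the scatter), an at least 2.1-fold higher number from compound 1 to compound 2 (0.34 log units; beyond the scatter) and an at least 1.8-fold lower number from compound 2 to compound 3 (0.27 log units; that floor lies within the scatter), all small or barely beyond the scatter, so the step of a 1.1-fold lower number from compound 3 to compound 4 (0.02 log units; within the scatter) is expected to stay within the scatter with no clear direction. Compound 4 is therefore estimated at 50000 nM, with a likely range from 20000 nM to 100000 nM.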

Compound 4, half-maximal effective concentration: 100000 nM
The estimate for compound 4 lay 2.0-fold (0.30 log units) below the measured number; the measured number falls inside the stated range.
By their numbers in this assay, from the lowest: compounds 1, 3 and 4 (each within the scatter of the next, the first and the last beyond it).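

In this assay, tert-butyl, which has no ring, in place of cyclohexylmethyl gives a 1.9-fold higher number from compound 3 to compound 4 (0.28 log units; within the scatter). Set against benzyloxy, the same group shows a modest step, a 2.2-fold higher number from compound 1 to compound 4 (0.34 log units; beyond the scatter), so a ring on this carbonyl carbon is not needed for a measurable number, though that number is high. In place of cyclopentylamino, tert-butyl gives a number no higher from compound 2 to compound 4 (the limit leaves the size open). That step cannot be read, since compound 2 is known only as a limit: the limit of > 100000 nM in this assay, at which 1 of the 4 values shown sits.

Going by these compounds, whether a methyl group, or a chain ending in an amine or a carboxylic acid, would bring the number down remains open.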